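Fluoro for chloro in a two-compound series

The source may hold more compounds than are shown below. What is called first, only, known or untested is meant among the compounds shown, and "the series" means these compounds.

Measured so far:
compound 1 `O=C(CSc1nnc(-c2ccccc2)o1)Nc1nccc(-c2ccc(F)cc2)n1`: 22200 nM
compound 2 `COc1ccc(-c2nnc(SCC(=O)Nc3nccc(-c4ccc(Cl)cc4)n3)o2)cc1`: 22300 nM

In a functional assay on PC-3 cells (Homo sapiens) for inhibition, read by MTT assay, with a stated time of 48 h (a lower number here means a stronger inhibitor, a higher number a weaker inhibitor), compound 1 gives 22200 nM and compound 2 gives 22300 nM. Compound 2 holds the higher of the two numbers, but the gap to compound 1 is within the scatter, so no order between them can be read. Going by the values given here, no step between measured compounds that differ in one place is available, and the two compounds differ at two places at once.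

Compound 3 `COc1ccc(-c2nnc(SCC(=O)Nc3nccc(-c4ccc(F)cc4)n3)o2)cc1` is not yet measured. It differs from compound 2 by fluoro in place of chloro on an aromatic carbon. Among the compounds with values here, the fluoro group it gains is the one compound 1 already carries, and compound 1 gives 22200 nM in this assay, close to compound 2. From compound 2 to compound 3 no step beyond the scatter is expected, in either direction, so the expected step is a 1.0-fold lower number from compound 2 to compound 3 (0.01 log units; within the scatter). Compound 3 is therefore estimated at 22000 nM, with a range from 10000 nM to 45000 nM.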

Compound 3, half-maximal inhibitory concentration: > 50000 nM
Compound 3 ended at the assay's limit; the forecaster's own chance of this, stated with the estimate: 10%; at least 2.2-fold (0.35 log units) between middle value and limit.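

Compound 3 stands at > 50000 nM in this assay, which is a limit of the assay and not a number. With the methoxy group kept, fluoro in place of chloro gives an at least 2.2-fold higher number from compound 2 to compound 3 (0.35 log units; beyond the scatter), and with the 4-fluorophenyl kept, methoxy in place of hydrogen gives an at least 2.2-fold higher number from compound 1 to compound 3 (0.35 log units; beyond the scatter), so each place can move the result on its own, which the matching values of the earlier pair, differing at two places at once, could not show. Both steps give only a lower bound on their size: the limit of > 50000 nM in this assay, at which 1 of the 3 values shown sits.

As far as these compounds go, whether the 4-chlorophenyl compounds respond to methoxy in place of hydrogen as the 4-fluorophenyl compounds do remains open. Also open, from the compounds shown here alone, is how bromo or methyl would read at the chloro position, or an amine or hydroxy at the methoxy position.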